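The compounds below may be only part of what the source reports. "The series", "measured", "known", "first", "only" and "open" are said of these compounds alone.

Measured compounds in a functional assay on HEK293 cells for positive allosteric modulation of metabotropic glutamate receptor 5 (Homo sapiens), read by calcium flux; a lower number here means a smaller maximal response, a higher number a larger maximal response:
compound 1, `O=C(c1ccccc1F)N1CCCn2nc(COc3ccccc3)cc21`, gives 62%
compound 2, `O=C(c1cccc(F)c1)N1CCCn2nc(COc3ccccc3)cc21`, gives 61%
compound 3, `O=C(c1ccccn1)N1CCCn2nc(COc3ccccc3)cc21`, gives 44%

Compound 3 stands lowest of the three in this assay. The two fluorophenyl compounds sit together, since the step of a number 1 percentage points lower from compound 1 to compound 2 (within the scatter) lies within the scatter. Compound 3 falls away from both: the steps of a number 18 percentage points lower from compound 1 to compound 3 (beyond the scatter) and a number 17 percentage points lower from compound 2 to compound 3 (beyond the scatter) are modest but beyond the scatter. In both of these steps, pyridin-2-yl takes the place of a fluorophenyl ring on the carbonyl carbon.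

Compound 4, `O=C(c1ccno1)N1CCCn2nc(COc3ccccc3)cc21`, is not yet measured. It differs from compound 3 in one place: 1,2-oxazol-5-yl in place of pyridin-2-yl on a carbonyl carbon. Among the compounds with values here, no measured step exchanges one heteroaryl ring for another on the carbonyl carbon, so the only steps that bear on this change do so indirectly: a number 18 percentage points lower from compound 1 to compound 3 (beyond the scatter) and a number 17 percentage points lower from compound 2 to compound 3 (beyond the scatter) show that moving from a fluorophenyl ring to a six-membered ring with one hetero atom lowered the maximal response modestly. Going on to a five-membered ring with two hetero atoms gives no measured precedent for direction, so compound 4 is expected to lie near compound 3, with the step of a number 2 percentage points lower from compound 3 to compound 4 (within the scatter) estimated to stay within the scatter. Compound 4 is estimated at 42%, between 27% and 57%.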

Compound 4, largest response reached (reported as percent of maximum), in percent of the reference or control that the assay uses: 22%
Compound 4: the middle estimate sits 20 percentage points above what was measured; measured number outside the range, below it.
By their numbers in this assay, from the lowest: compound 4; then compound 3; then compounds 2 and 1 (each within the scatter of the next).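

In this assay, within the data shown here, the exchange of one heteroaryl ring for another on the carbonyl carbon proves to be no neutral step: 1,2-oxazol-5-yl in place of pyridin-2-yl gives a number 22 percentage points lower from compound 3 to compound 4 (beyond the scatter) and so shows that this position separates two heteroaryl rings, and not only a fluorophenyl ring from a pyridin-2-yl ring. Set against the fluorophenyl rings, the same 1,2-oxazol-5-yl group gives a number 39 percentage points lower from compound 2 to compound 4 (beyond the scatter) and a number 40 percentage points lower from compound 1 to compound 4 (beyond the scatter), the first large steps seen here, so a change at this one place spans far more of the maximal response than the three earlier compounds revealed. Nothing at hand accounts for the difference between these rings.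

With only one five-membered ring in the set, the compounds shown leave open whether other such rings, for instance 1,3-thiazol-2-yl or furan-2-yl, would keep the response as low as compound 4 does. They also leave open what a saturated group such as cyclohexyl, a simple alkyl chain or an amine on the same carbonyl carbon would do to the maximal response.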